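The compounds below may be only part of what the source reports. "The series", "measured", "known", "first", "only" and "open" are said of these compounds alone.

Measured so far in an in vitro functional assay on HEK293-A cells for negative allosteric modulation of metabotropic glutamate receptor 5 (Homo sapiens), read by FLIPR and calcium flux; a higher number here means a weaker inhibitor, a lower number a stronger inhibitor:

Compound 1 `O=C1CC(c2nc(-c3cccc(Cl)c3)no2)CN1c1cccc(Cl)c1`: 1100 nM
Compound 2 `CC(C)CN1CC(c2nc(-c3cccc(Cl)c3)no2)CC1=O`: 920 nM
Compound 3 `O=C1COc2ccccc2N1Cc1nc(-c2cccc(Cl)c2)no1`: 770 nM

Compound 2 holds the second highest of the three numbers, yet all three lie within the scatter of one another, so no order among compounds 1, 2 and 3 can be read from them in this assay. Among the compounds with values here, the only single-point step among them is a 1.2-fold lower number from compound 1 to compound 2 (0.08 log units; within the scatter), which replaced 3-chlorophenyl with isobutyl on the amide-type nitrogen in the ring and moved the number no further than repeated measurement would.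

Compound 4 `O=C1CC(c2nc(-c3cccc(Cl)c3)no2)CN1Cc1ccc(F)cc1` is the next candidate. It differs from compound 2 as follows: 4-fluorophenyl in place of isopropyl on a saturated chain carbon bound to an amide-type nitrogen in a ring.

Within the data shown here, the step from compound 1 to compound 2 is the one measured change at this part of the shared core, and it was within the scatter. It swapped an aromatic ring for a branched chain at the nitrogen itself; the new change goes the other way, a chain to an aromatic ring, one bond further out. Among the measured compounds shown here, with a single flat step as the only guide, no move beyond the scatter is expected in this assay for compound 4, in either direction, giving an estimated 1.0-fold lower number from compound 2 to compound 4 (0.01 log units; within the scatter). Compound 4 is thus expected at 900 nM, within 400 nM to 2000 nM.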

Compound 4, half-maximal inhibitory concentration in the metabotropic glutamate receptor 5 assay: 3600 nM
Compound 4: the middle estimate sits 4.0-fold (0.60 log units) below what was measured; the measured number lies above the stated range.
By their numbers in the metabotropic glutamate receptor 5 assay, from the lowest: compounds 3, 2 and 1 (each within the scatter of the next); then compound 4.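

Notes on the amide-type nitrogen in a ring: in the metabotropic glutamate receptor 5 assay, this position is no longer flat, since a 3.9-fold higher number from compound 2 to compound 4 (0.59 log units; beyond the scatter) and a 3.3-fold higher number from compound 1 to compound 4 (0.51 log units; beyond the scatter), whereas the earlier step at the same nitrogen stayed within the scatter. 4-Fluorobenzyl therefore separates from both isobutyl and 3-chlorophenyl, which shows that this position does respond to the group placed on it, and that an aromatic ring directly on the nitrogen and one carried on a saturated chain carbon are not interchangeable here. In a physicochemical assay for solubility, read by HPLC (a lower number here means a less soluble compound, a higher number a more soluble compound), compound 2 gives 23000 nM and compound 4 gives 23000 nM, so that no change at the digits printed from compound 2 to compound 4 (within the scatter), and nothing in the data shown accounts for the step in either assay.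

Open, on these data alone, is whether the higher number follows the fluorine or the aromatic ring itself, a question that plain benzyl and cyclohexylmethyl on the same nitrogen would separate. Also open, as far as these compounds go, is how far the position tolerates size in a saturated group, as a longer chain such as n-pentyl would show against isobutyl.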